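Aldosterone synthase inhibitors: acetamide to propanamide on compound 1

The compounds below may be only part of what the source reports. "The series", "measured", "known", "first", "only" and "open" are said of these compounds alone.

Measured compounds:
- compound 1, `CC[C@H]1c2cc(Cl)ccc2C(=O)N1c1cncc2c1CCC[C@H]2NC(C)=O`: 97 nM
- compound 2, `Cn1cc(C(=O)N2CC3(C2)CN(c2cncc(N4C(=O)c5ccc(Cl)cc5C4(C)C)c2)C3)cn1`: 2 nM
- compound 3, `CC(=O)N1CC2(C1)CN(c1cncc(N3C(=O)c4ccc(Cl)cc4C3(C)C)c1)C2`: 23 nM

In an assay on cells for inhibition of cytochrome P450 11B2, mitochondrial (Homo sapiens), read by HTRF (a lower number here means a stronger inhibitor, a higher number a weaker inhibitor), compound 1 gives the highest number of the three, and its distances to compound 3 and to compound 2 both lie beyond the scatter, so it is the weakest inhibitor of the measured set. Among the compounds with values here, compound 2 and compound 3 share a core different from that of compound 1; the one step between them, a 12-fold higher number from compound 2 to compound 3 (1.06 log units; beyond the scatter), is the only measured step in the set and concerns the group on a carbonyl carbon of an amide.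

Compound 4, `CCC(=O)N[C@@H]1CCCc2c1cncc2N1C(=O)c2ccc(Cl)cc2[C@@H]1CC`, differs from compound 1 by methyl in place of hydrogen on a saturated chain carbon bound to a carbonyl carbon. The step from compound 2 to compound 3 touches the same kind of position, the substituent carried by an amide carbonyl, but there a ring left and a methyl entered; here only a methyl is added to a methyl already present, so that step gives no direct measure. Within the data shown here, no measured pair shows a hydrogen-to-methyl change on a saturated chain carbon, so the expected step is small. Compound 4 is expected to lie close to compound 1, with the step of a 1.1-fold lower number from compound 1 to compound 4 (0.06 log units; within the scatter) judged to remain within the scatter. The estimate for compound 4 is 85 nM, in the range 40 nM to 200 nM.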

Compound 4, half-maximal inhibitory concentration: 12 nM
Beside the measured number, compound 4's estimate is 7.1-fold (0.85 log units) above it; the whole stated range lies above it.
By their numbers in this assay, from the lowest: compound 2; then compounds 4 and 3 (each within the scatter of the next); then compound 1.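

In this assay, within the data shown here, the change from acetamido to propanoylamino on the core of compound 1 gives an 8.1-fold lower number from compound 1 to compound 4 (0.91 log units; beyond the scatter), so this position responds to the addition of a single methyl on a saturated chain carbon bound to a carbonyl carbon, which the earlier compounds could not show. Among these compounds, until now the only measured change at a group carried by an amide carbonyl was a 12-fold higher number from compound 2 to compound 3 (1.06 log units; beyond the scatter), on a different core and with a ring leaving; in both steps the larger group on the carbonyl carbon carries the lower number, though two pairs on two cores do not make a trend. Nothing available here accounts for the effect of the added methyl.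

The compounds shown leave open whether a longer chain, such as butanoyl, or a branched group, such as isopropyl or cyclopropyl on the carbonyl carbon, would lower the number further on the core of compound 1 or reverse the step. They also leave open how the 1-methyl-1H-pyrazol-4-yl group of compound 2 would behave on the carbonyl carbon of that core.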